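A few compounds are considered here, and "the series" means these few. Any claim that something is new, unique, unknown or untested is made for them only; others in the source may bear on it.

Values in a functional assay on HUVEC cells (Homo sapiens), read by BrdU incorporation, with a stated time of 72 h; a higher number here means a weaker inhibitor, a lower number a stronger inhibitor:
compound 1 `Cc1ccc2nc(Cl)c(/C=C/C(=O)c3sccc3Cl)cc2c1` gives 37.5 nM
compound 2 `Cc1ccc2nc(Cl)c(/C=C/C(=O)c3cc(C)sc3C)cc2c1` gives 229 nM
compound 3 `Cc1ccc2nc(Cl)c(/C=C/C(=O)c3ccc(Br)s3)cc2c1` gives 88.4 nM

Compound 3 holds the middle position of the three, with compound 1 lower and compound 2 higher, and both gaps lie beyond the scatter. The next compound is compound 4 `Cc1ccc2nc(Cl)c(/C=C/C(=O)c3ccc(C)s3)cc2c1`, which has methyl in place of bromo on an aromatic carbon, so that 5-bromothiophen-2-yl becomes 5-methylthiophen-2-yl: methyl in place of bromo on an aromatic carbon. The swap sits on an aromatic carbon of a five-membered aromatic ring with 1 sulfur, next to the ring sulfur.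

Going by the values given here, no measured step isolates this swap. The nearest evidence is a 2.4-fold higher number from compound 1 to compound 3 (0.37 log units; beyond the scatter) and a 2.6-fold lower number from compound 2 to compound 3 (0.41 log units; beyond the scatter). Both are modest, and each exchanges a whole substituted thiophene group rather than one substituent. Among the compounds with values here, compound 2, the only measured compound carrying methyl groups on the ring, gives 229 nM, which is weak support for a move to a higher number, since its attachment point also differs. The expected step is a 1.4-fold higher number from compound 3 to compound 4 (0.13 log units; within the scatter), a small rise not expected to exceed the scatter. For compound 4 the estimated value in this assay is 120 nM, with an expected range of 45 nM to 320 nM.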

Compound 4, half-maximal inhibitory concentration: 128 nM
Compound 4: middle estimate off by 1.1-fold (0.03 log units), on the low side; the range from low to high includes it.
By their numbers in this assay, from the lowest: compound 1; then compounds 3, 4 and 2 (each within the scatter of the next, the first and the last beyond it).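

In this assay, going by these compounds alone, methyl in place of bromo is the first change confined to a single substituent, on an aromatic carbon of a five-membered aromatic ring with 1 sulfur, next to the ring sulfur, and the step stays within the scatter (a 1.4-fold higher number from compound 3 to compound 4 (0.16 log units; within the scatter)). Within the data shown here, the 5-methylthiophen-2-yl group is likewise not separated from the 2,5-dimethylthiophen-3-yl group (a 1.8-fold lower number from compound 2 to compound 4 (0.25 log units; within the scatter)), whereas the 3-chlorothiophen-2-yl group stands apart from it beyond the scatter (a 3.4-fold higher number from compound 1 to compound 4 (0.53 log units; beyond the scatter)), so compound 1 is the only one of the three comparisons that separates from compound 4. No measurement at hand gives a reason for any of these steps.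

Still open, from the compounds shown here alone, is whether a different group on this carbon, such as an amine, a carboxylic acid or a longer alkyl chain, would carry the number beyond the scatter of bromo and methyl. Also open is whether the gap to compound 1 belongs to the chloro group or to its place on the ring: no pair shown separates the two.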